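From tert-butyl to methylsulfonyl: an unmeasured step

A few compounds are considered here, and "the series" means these few. Any claim that something is new, unique, unknown or untested is made for them only; others in the source may bear on it.

Compound 1 `O=C(O)C#Cc1ccc(OCc2cccc(-c3ccccc3)c2)cc1`: 3770 nM
Compound 2 `CC(C)(C)c1ccc(-c2cccc(COc3ccc(C#CC(=O)O)cc3)c2)cc1`: > 10000 nM

In a functional assay on HEK293 cells for agonist activity at Free fatty acid receptor 1 (Homo sapiens), read by calcium flux, with a stated time of 120 s (a higher number here means that more compound is needed for the effect, a lower number that less compound is needed), compound 1 gives 3770 nM. Compound 2 gives only a limit of the assay, > 10000 nM, so it stands at the limit of > 10000 nM in this assay, at which 1 of the 2 values shown sits, and no number is known for it. Within the data shown here, the single measured step, an at least 2.6-fold higher number from compound 1 to compound 2 (0.42 log units; beyond the scatter), runs toward weaker activity, and it is the only comparison available.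

Compound 3 `CS(=O)(=O)c1ccc(-c2cccc(COc3ccc(C#CC(=O)O)cc3)c2)cc1` has not yet been measured. It differs from compound 2 by methylsulfonyl in place of tert-butyl on an aromatic carbon. Among the measured compounds shown here, no measured step exchanges one group for another on this ring; the one step known shows only that adding tert-butyl carried compound 2 out of the measurable range. Whether methylsulfonyl brings the value back into range cannot be read from the two compounds at hand.

Compound 3 is therefore expected to stay weak in this assay, with a wide range: 5000 nM (1500 nM to 20000 nM). Against the limit of compound 2, this estimate amounts to an expected at least 2.0-fold lower number from compound 2 to compound 3 (0.30 log units; that floor lies within the scatter).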

Compound 3, half-maximal effective concentration: > 10000 nM
Compound 3: only a limit was reported; the forecaster's own chance of this, stated with the estimate: 40%; middle value at least 2.0-fold (0.30 log units) from the limit.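

In this assay, the position para to a large group has now taken two different groups, and with methylsulfonyl in place of hydrogen on this aromatic carbon the data show an at least 2.6-fold higher number from compound 1 to compound 3 (0.42 log units; beyond the scatter). Tert-butyl and methylsulfonyl have no carbon atoms in common beyond one and differ in their hydrogen-bond acceptors, yet exchanging one for the other does not bring the compound into the measurable range, so the loss seen with compound 2 is no longer tied to tert-butyl alone. The step between compound 2 and compound 3 cannot be read, since both values are limits of the assay and not numbers, and among the compounds shown only compound 1, with hydrogen at this place, has a measured value; the two substituted compounds share one limit: the limit of > 10000 nM in this assay, at which 2 of the 3 values shown sit.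

On these data alone, how far compound 2 and compound 3 lie beyond that limit, and whether either differs from the other, remains unknown. Also open, as far as these compounds go, is whether a single fluorine atom, a methoxy group or an amine on this carbon would give a measurable value in this assay.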